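A few compounds are considered here, and "the series" means these few. Any claim that something is new, unique, unknown or untested is made for them only; others in the source may bear on it.

Measured compounds:
- compound 1 `CC(=O)CC/C=C(\C)CCC1=C(C)CCCC1(C)C`: > 15000 nM
- compound 2 `C=C1CCCC(C)(C)C1CC[C@]1(C)CC[C@H]([C@@H](C)C(=O)OC)OO1`: 270 nM
- compound 3 `C=C1CCC[C@H]2[C@](C)(CC[C@]3(C)CC[C@@H]([C@@H](C)C(=O)O)OO3)[C@@H](C)CC[C@]12C`: 500 nM

All three were tested in a functional assay on 786-0 cells (Homo sapiens) for inhibition; on this read-out lower numbers stand for stronger inhibition of growth and higher numbers for weaker inhibition of growth. For compound 1 the value > 15000 nM is a limit of the assay and not a number (the limit of > 15000 nM in this assay, at which 1 of the 3 values shown sits). Compound 2 gives 270 nM in this assay. Compound 3 gives 500 nM in this assay; the two numbers for compound 2 and compound 3 sit within the usual scatter of each other, so neither can be called the more potent. Compound 3 thus stands among the two measured compounds that return a number, with compound 1 at a limit.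

The next compound, compound 4 `C=C1CCC[C@H]2[C@](C)(CC[C@]3(C)CC[C@H]([C@@H](C)C(=O)O)OO3)[C@@H](C)CC[C@]12C`, is not yet measured. Against compound 3 it shows (the two compounds have the same atoms and bonds and differ only in configuration as drawn: 1 of 7 stereo elements differ; a stereocentre at a saturated ring carbon is drawn S in compound 3 and R in compound 4). Among the measured compounds shown here, no comparable pair of measured compounds, differing only in this way, is available, so the size and direction of the step cannot be taken from the data. With the atoms and bonds unchanged, the step in this assay is expected to be small, most likely none beyond the scatter, with either direction possible. For compound 4 the expected value is 800 nM, estimated within 250 nM to 2500 nM. This estimate for compound 4 means a step of a 1.6-fold higher number from compound 3 to compound 4 (0.20 log units; within the scatter) in this assay.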

Compound 4, concentration for 50% growth inhibition: 610 nM
The estimate for compound 4 lay 1.3-fold (0.12 log units) above the measured number; the range from low to high includes it.
By their numbers in this assay, from the lowest: compounds 2, 3 and 4 (each within the scatter of the next, the first and the last beyond it). At a limit, above all of these: compound 1.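

In this assay, among the compounds shown here, changing a stereocentre at a saturated ring carbon from S to R gives a 1.2-fold higher number from compound 3 to compound 4 (0.09 log units; within the scatter), the first step that can be read between compounds differing in one place. This step can be read as the effect of that one stereocentre alone, as nothing else changes: the fact that compounds 3 and 4 differ only in the configuration as drawn At this position, both configurations return a number within the scatter of each other, so in this pair the read-out does not separate the two drawn forms.

As far as these compounds go, it remains open whether the other stereo elements of the shared core and side chain would be equally without effect on the read-out, as this pair speaks for only one of them. From the compounds shown here alone, it is also open how this assay would respond if the carboxylic acid of compound 3 and compound 4 gave way to a primary amide or an amine, with either configuration at this ring carbon.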